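The compounds below may be only part of what the source reports. "The series", "measured", "known", "first", "only" and "open" are said of these compounds alone.

Series notes, acyl-CoA desaturase inhibition. Within the data shown here, in an assay on microsomes from liver for inhibition of acyl-CoA desaturase 1 (Rattus norvegicus) (on this read-out higher numbers stand for weaker inhibition and lower numbers for stronger inhibition), compound 1 `CCc1ccccc1OC1CCN(c2ccc(-n3ccnc3)nn2)CC1` gives 4 nM and compound 2 `Brc1cccc(OC2CCN(c3ccc(-n4ccnc4)nn3)CC2)c1` gives 23 nM; the one measured step, a 5.8-fold higher number from compound 1 to compound 2 (0.76 log units; beyond the scatter), concerns the aryl ether only. Compound 3 `CC(C)(C)c1nnc(-c2ccc(N3CCC(Oc4ccccc4C(F)(F)F)CC3)nn2)o1` gives 980 nM in this assay, the highest number of the three, with compound 2 nearer to it and compound 1 furthest away. Compound 4 `Cc1nnc(-c2ccc(N3CCC(Oc4ccccc4C(F)(F)F)CC3)nn2)s1` carries 5-methyl-1,3,4-thiadiazol-2-yl in place of 5-(tert-butyl)-1,3,4-oxadiazol-2-yl on an aromatic carbon. Among the measured compounds shown here, no measured step touches this position, so no direction is indicated by the data; the step is treated as uncertain and, as an estimate, a 1.6-fold lower number from compound 3 to compound 4 (0.21 log units; within the scatter) is expected. The expected value for compound 4 in this assay is 600 nM, within 150 nM to 3000 nM.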

Compound 4, half-maximal inhibitory concentration: 2.3 nM
For compound 4 the middle estimate is 260-fold (2.42 log units) above the measured one; the measured number lies below the stated range.
By their numbers in this assay, from the lowest: compounds 4 and 1 (each within the scatter of the next); then compound 2; then compound 3.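

Among these compounds, this position matters far more than the single aryl ether step suggested: in this assay, 5-methyl-1,3,4-thiadiazol-2-yl in place of 5-(tert-butyl)-1,3,4-oxadiazol-2-yl gives a 430-fold lower number from compound 3 to compound 4 (2.63 log units; beyond the scatter). The step changes the ring and its substituent together, so their separate contributions cannot be read from it. Nothing available accounts for the size of this step.

From the compounds shown here alone, it remains open whether the step follows the thiadiazole ring or the methyl group; 5-methyl-1,3,4-oxadiazol-2-yl and 5-(tert-butyl)-1,3,4-thiadiazol-2-yl would separate the two. Also open, going by these compounds, is how an amine or a carboxylic acid on this five-membered ring would read out.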